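Methoxy for Fluoro on Two Related Cores

A few compounds are considered here, and "the series" means these few. Any claim that something is new, unique, unknown or untested is made for them only; others in the source may bear on it.

Measured compounds:
compound 1 `COC(=O)[C@@]1(C)CCC=C2[C@@H]1CC[C@@H](C)[C@]2(C)Cc1c(C)[nH]c2ccc(F)cc12`: 17000 nM
compound 2 `COC(=O)[C@@]1(C)CCC=C2[C@@H]1CC[C@@H](C)[C@]2(C)Cc1c(C)[nH]c2ccc(OC)cc12`: 17000 nM
compound 3 `COC(=O)[C@@]1(C)CC[C@@H]2C3=C1CC[C@@H](C)[C@]3(C)C[C@@H]1c3cc(F)ccc3N[C@H]21`: 32000 nM

In a functional assay on WiDr cells (Homo sapiens) for inhibition, read by sulforhodamine B assay, with a stated time of 48 h (on this read-out higher numbers stand for weaker inhibition of growth and lower numbers for stronger inhibition of growth), compound 1 gives 17000 nM. Compound 2 carries the change methoxy in place of fluoro on an aromatic carbon and in this assay compound 2 gives 17000 nM, so no change at the digits printed from compound 1 to compound 2 (within the scatter). Compound 3 has a different core; how the two cores differ is not broken down here. In this assay compound 3 gives 32000 nM, and its values and those of compounds 1 and 2 lie within the scatter of one another.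

Compound 4 `COC(=O)[C@@]1(C)CC[C@@H]2C3=C1CC[C@@H](C)[C@]3(C)C[C@@H]1c3cc(OC)ccc3N[C@H]21` is not yet measured. It differs from compound 3 by methoxy in place of fluoro on an aromatic carbon. This is the same kind of change as from compound 1 to compound 2, though the ring bearing it is part of a fused or bridged system of five rings rather than two. Because no change at the digits printed from compound 1 to compound 2 (within the scatter), the expected step in this assay is no change at the digits printed from compound 3 to compound 4 (within the scatter). Compound 4 is therefore estimated at 32000 nM, expected between 15000 nM and 65000 nM.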

Compound 4, concentration for 50% growth inhibition: 25000 nM
Compound 4: the middle estimate sits 1.3-fold (0.11 log units) above what was measured; the measured number falls inside the stated range.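

In this assay, putting methoxy in place of fluoro on the core of compound 3 gives a 1.3-fold lower number from compound 3 to compound 4 (0.11 log units; within the scatter). Set beside the earlier step, the swap behaves alike on the two cores: the same change on two cores in this assay, no change at the digits printed (within the scatter) from compound 1 to compound 2 and a 1.3-fold lower number (0.11 log units; within the scatter) from compound 3 to compound 4, 1.3-fold (0.11 log units) apart, within the scatter of two such steps

Going by these compounds alone, this agreement is between two steps that are both too small to read as real effects, so it shows only that this one swap leaves growth inhibition about where it was on both cores. It does not show that a change with a clear effect on one core would carry over to the other, or that the same quiet result would appear on a third core.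

The compounds shown carry only fluoro or methoxy on this aromatic carbon, so it remains open whether an amine, a carboxylic acid or a longer chain such as butoxy would move the number beyond the scatter. On these data alone, it also remains open whether the two cores would still respond alike to such a group.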